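The source may hold more compounds than are shown below. What is called first, only, known or untested is meant among the compounds shown, and "the series" means these compounds.

The compounds share one core and vary at the aryl group on an oxygen on a saturated carbon. Compound 1 `NC1=NC2(CCSCC2)N(OCCCOc2cccc(Cl)c2)C(N)=N1` gives 88.3% in an assay on isolated protein for inhibition of Dihydrofolate reductase (Homo sapiens), read by spectrophotometry, using NADPH, with stated times of 5 s and 6 min, tested at 5 uM; a lower number here means a weaker effect, a higher number a stronger effect of the compound at the concentration tested. Compound 3 `NC1=NC2(CCSCC2)N(OCCCOc2cc(Cl)c(Cl)cc2Cl)C(N)=N1` gives 84.4% in this assay, and the step of a number 3.9 percentage points lower from compound 1 to compound 3 (within the scatter) shows that 2,4,5-trichlorophenyl in place of 3-chlorophenyl on an oxygen on a saturated carbon left the read-out where it was. Compound 2 `NC1=NC2(CCOCC2)N(OCCCOc2ccc(Cl)c(Cl)c2)C(N)=N1` stands at a limit of the assay in this assay, reported as > 90%. Its value is one of those sitting at the limit (the limit of > 90% in this assay, at which 1 of the 3 values shown sits), so no exact number is known for it.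

The unmeasured compound 4 `Cc1cc(C)cc(OCCCON2C(N)=NC(N)=NC23CCOCC3)c1` differs from compound 2 in one place (3,5-dimethylphenyl in place of 3,4-dichlorophenyl on an oxygen on a saturated carbon). Among the measured compounds shown here, the only measured step that bears on it is that from compound 1 to compound 3, also a change of substituents on that aryl ring, and it lay within the scatter. For the measured compounds named here, no measured compound carries methyl groups on that ring, so the data give no direct guide for this change. Compound 4 is therefore expected to remain a strong inhibitor in this assay, with an estimated step of a number at least 6 percentage points lower from compound 2 to compound 4 (that floor lies within the scatter) and an estimated inhibition of 84%, between 68% and 93%.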

Compound 4, a percentage reported as inhibition, at one concentration (the size of the read-out at that concentration, not a potency): 84.3%
Beside the measured number, compound 4's estimate is 0.3 percentage points below it; low and high end bracket the measured number.
By their numbers in this assay, from the lowest: compounds 4, 3 and 1 (each within the scatter of the next). At a limit, above all of these: compound 2.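

The earlier compounds shown here all carried chlorine on the aryl ring, so they could not show whether a ring without it would still give a high read-out. Compound 4 shows that it can: in this assay, 3,5-dimethylphenyl in place of 3,4-dichlorophenyl on an oxygen on a saturated carbon gives a number at least 5.7 percentage points lower from compound 2 to compound 4 (that floor lies within the scatter), so at this position a high read-out does not depend on chlorine. The true size of that step remains unknown, because compound 2 stands at a limit and the step is only a floor: the limit of > 90% in this assay, at which 1 of the 4 values shown sits.

What the compounds shown leave open is whether the read-out would hold with groups of another kind on this ring, such as an amine or a carboxylic acid, or with a longer chain between the ring and the shared core. Each read-out also comes from a single concentration, so these results do not show how the compounds would compare in potency, and they do not show what a ring carrying neither chlorine nor methyl would give.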